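From compound 3 to compound 4: methyl for chloro

The source may report more compounds than this note shows. Statements on the series, on what has been measured and on what is new or still open speak of the compounds shown alone.

Measured in an in vitro ADME assay on microsomes from liver (Homo sapiens) for pharmacokinetics, read by LC-MS, with a stated time of 10 min, tested at 1 uM; a lower number here means slower removal, a higher number faster removal of the compound:
Compound 1 `Cc1ccc(NC(=O)[C@H]2CN(C)C[C@@H]2c2ccc(/C=C/C(=O)Nc3ccccc3N)cc2)cc1`: 15 mL/min/kg
Compound 2 `CN1C[C@H](C(=O)Nc2ccc(C3CC3)cc2)[C@@H](c2ccc(/C=C/C(=O)Nc3ccccc3N)cc2)C1`: 12 mL/min/kg
Compound 3 `CN1C[C@H](C(=O)Nc2ccc(Cl)c(Cl)c2)[C@@H](c2ccc(/C=C/C(=O)Nc3ccccc3N)cc2)C1`: 14 mL/min/kg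

Compound 3 stands at 14 mL/min/kg, within the scatter of the other two measured compounds. Compound 4 `Cc1cc(NC(=O)[C@H]2CN(C)C[C@@H]2c2ccc(/C=C/C(=O)Nc3ccccc3N)cc2)ccc1Cl` differs from it in one place: methyl in place of chloro on an aromatic carbon. In words, 3,4-dichlorophenyl becomes 4-chloro-3-methylphenyl. Within the data shown here, no measured step makes exactly this change. The closest, a 1.1-fold lower number from compound 1 to compound 3 (0.03 log units; within the scatter), also alters the group on the amide-type nitrogen, as does a 1.2-fold higher number from compound 2 to compound 3 (0.07 log units; within the scatter), while a 1.3-fold lower number from compound 1 to compound 2 (0.10 log units; within the scatter) alters a group on an aromatic carbon. All three stay within the scatter, so no shift beyond it is expected in this assay. The expected step is no change at the digits printed from compound 3 to compound 4 (within the scatter). For compound 4 the estimated clearance is 14 mL/min/kg, with an expected range of 8 mL/min/kg to 23 mL/min/kg.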

Compound 4, clearance: 15 mL/min/kg
Beside the measured number, compound 4's estimate is 1.1-fold (0.03 log units) below it, and the stated range covers the measured number.
By their numbers in this assay, from the lowest: compounds 2, 3, 1 and 4 (each within the scatter of the next).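

In this assay methyl in place of chloro on this aromatic carbon, ortho to a chloro group, gives a 1.1-fold higher number from compound 3 to compound 4 (0.03 log units; within the scatter) and so shows directly that this exchange at this position brings no shift beyond the scatter. Both a 1.3-fold higher number from compound 2 to compound 4 (0.10 log units; within the scatter) and no change at the digits printed from compound 1 to compound 4 (within the scatter) also stay within the scatter, so 4-chloro-3-methylphenyl reads like the other groups on the amide-type nitrogen. No evidence bears on this result. The compounds shown leave open how an amine, a carboxylic acid or a longer alkyl chain would read at this position.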